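The compounds below may be only part of what the source reports. "The series", "measured", "known", "first", "only" and "open" are said of these compounds alone.

Working notes on the series. All three measured compounds share one core, seen in compound 1 `O=C(/C=C/c1ccc(OCc2cn(Cc3ccccc3Br)nn2)cc1)c1ccc(Br)cc1`, compound 2 `O=C(/C=C/c1ccc(OCc2cn(Cc3ccc(Br)cc3)nn2)cc1)c1ccc(Br)cc1` and compound 3 `O=C(/C=C/c1ccc(OCc2cn(Cc3ccccc3F)nn2)cc1)c1ccc(Br)cc1`. In a functional assay on A549 cells (Homo sapiens) for inhibition, read by MTT assay, with a stated time of 48 h, tested at 10 uM (on this read-out higher numbers stand for more inhibition of growth at the one concentration tested and lower numbers for less inhibition of growth), compound 1 gives 44%, the highest of the three numbers; compound 2 gives 27% and compound 3 gives 38%. The step of a number 17 percentage points lower from compound 1 to compound 2 (beyond the scatter) lies beyond the scatter, the step of a number 6 percentage points lower from compound 1 to compound 3 (within the scatter) within it, and a number 11 percentage points higher from compound 2 to compound 3 (beyond the scatter) beyond it. Compound 4 `COc1ccc(C(=O)/C=C/c2ccc(OCc3cn(Cc4ccccc4Br)nn3)cc2)cc1` differs from compound 1 by methoxy in place of bromo on an aromatic carbon. For the measured compounds named here, no measured step touches this aromatic carbon; the only substituent swap on an aromatic carbon measured so far, a number 6 percentage points lower from compound 1 to compound 3 (within the scatter), stayed within the scatter. A step within the scatter is therefore expected, a number 4 percentage points lower from compound 1 to compound 4 (within the scatter). Compound 4 is estimated at 40%, between 25% and 55%.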

Compound 4, percent growth inhibition at one concentration: 52%
The estimate for compound 4 lay 12 percentage points below the measured number; the measured number falls inside the stated range.
By their numbers in this assay, from the lowest: compound 2; then compounds 3, 1 and 4 (each within the scatter of the next, the first and the last beyond it).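

For the compounds shown here, this is the first measured change at the aromatic carbon para to a large group in the 4-bromophenyl ring: in this assay, the swap to 4-methoxyphenyl reads a number 8 percentage points higher from compound 1 to compound 4 (within the scatter) and so does not separate methoxy from bromo here. The entering group adds one hydrogen-bond acceptor, yet the number stays within the scatter. Nothing available bears on the reason for this result.

Open, from the compounds shown here alone, is whether an amine, a carboxylic acid or a longer alkoxy chain at this carbon would give a step beyond the scatter. Also open, going by these compounds, is whether the same swap reads alike on the cores of compound 2 and compound 3.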